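The source may report more compounds than this note shows. Statements on the series, on what has been measured and on what is new or still open speak of the compounds shown alone.

Measured compounds:
- compound 1 `COc1ccc(-c2ccn(CCC(C)C)c(=O)c2C#N)cc1`: 160%
- compound 2 `COc1ccc(-c2ccn(CCC(C)C)c(=O)c2C#N)cc1F`: 160%
- compound 3 `COc1ccc(-c2ccn(CCC(C)C)c(=O)c2C#N)cc1OC`: 242%

All three share one core and differ only on the aromatic ring that carries the methoxy group. In a functional assay on CHO cells for positive allosteric modulation of metabotropic glutamate receptor 2 (Homo sapiens), read by scintillation counting and GTPgammaS binding, with a stated time of 30 min (a lower number here means a smaller maximal response, a higher number a larger maximal response), compound 1 gives 160%, and it stands level with compound 2, the two together forming the lowest pair of the three, since no change at the digits printed from compound 1 to compound 2 (within the scatter). Compound 3 stands furthest away, with a number 82 percentage points higher from compound 1 to compound 3 (beyond the scatter) and, seen from the fluoro compound, a number 82 percentage points higher from compound 2 to compound 3 (beyond the scatter).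

The next compound, compound 4 `CC(C)CCn1ccc(-c2ccc(Oc3cccnc3)cc2)c(C#N)c1=O`, changes a different spot: pyridin-3-yl in place of methyl on an oxygen on an aromatic ring. Going by the values given here, no measured step touches the oxygen itself; the steps from compound 1 to compounds 2 and 3 only swap a hydrogen on the ring. They show that the ring tolerates change, once without effect and once with a large rise, so they give the direction of the new step only loosely. With nothing acting on the methyl of the methoxy among the measured compounds, the expected step is a number 10 percentage points higher from compound 1 to compound 4 (within the scatter), small and within the scatter. Compound 4 is therefore estimated at 170% in this assay, with a likely range from 110% to 250%.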

Compound 4, largest response reached (Emax), in percent of the reference or control that the assay uses: 231%
The estimate for compound 4 lay 61 percentage points below the measured number, within the range that was stated.
By their numbers in this assay, from the lowest: compounds 1 and 2 (each within the scatter of the next); then compound 4; then compound 3.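

The methyl on the oxygen of compound 1 proves not to be essential for the response: in this assay, replacing it with pyridin-3-yl gives a number 71 percentage points higher from compound 1 to compound 4 (beyond the scatter) and is a large step. The earlier steps shown here changed only a hydrogen on the aromatic ring, whereas this one shows that the group on the oxygen can itself be exchanged for a whole six-membered aromatic ring, with a higher maximal response rather than a loss. Nothing in the data shown explains this rise.

Going by these compounds alone, the single step cannot separate the contribution of the added ring from that of its nitrogen, and a phenyl group on the same oxygen would be the direct comparison for telling the two apart. On these data alone, it also remains open how the response changes between the methyl and the ring, for example with an ethyl or a cyclopropyl group on the oxygen, and whether a benzyl group, which places a carbon between the oxygen and the ring, would give a similar number.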